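Ester to amide on the trifluoromethyl compound

The compounds below may be only part of what the source reports. "The series", "measured", "known", "first", "only" and "open" are said of these compounds alone.

Measured in an ADME assay on HeLa cells (Homo sapiens) for cytotoxicity, read by crystal violet staining, with a stated time of 72 h (on this read-out higher numbers stand for lower toxicity in this test and lower numbers for higher toxicity in this test), so far
- compound 1 `CCOC(=O)c1cc(CCCOc2ccc(-c3noc(C(F)(F)F)n3)cc2[N+](=O)[O-])on1` gives > 100000 nM (a limit of the assay)
- compound 2 `CCOC(=O)c1cc(CCCOc2ccc(-c3noc(C(F)(F)F)n3)cc2F)on1` gives 60200 nM
- compound 3 `CCOC(=O)c1cc(CCCOc2ccc(-c3noc(C(F)(F)F)n3)cc2C(F)(F)F)on1` gives 28400 nM

The lowest of the two actual numbers belongs to compound 3, and the gap to its nearest neighbour is a 2.1-fold lower number from compound 2 to compound 3 (0.33 log units; beyond the scatter) on swapping groups on an aromatic carbon. The change to compound 4 `CN(C)C(=O)c1cc(CCCOc2ccc(-c3noc(C(F)(F)F)n3)cc2C(F)(F)F)on1` is dimethylamino in place of ethoxy on a carbonyl carbon. For the measured compounds named here, no measured step touches this carbonyl. Going by the values given here, the only guides are the aromatic-carbon steps, an at least 3.5-fold lower number from compound 1 to compound 3 (0.54 log units; beyond the scatter) and a 2.1-fold lower number from compound 2 to compound 3 (0.33 log units; beyond the scatter), which suggest a size but no direction. A modest step upward is expected, with compound 3 at 28400 nM the low end of the series. The estimated change is a 1.8-fold higher number from compound 3 to compound 4 (0.25 log units; within the scatter) in this assay terms. Compound 4 is estimated at 50000 nM (range 17000 nM to 100000 nM).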

Compound 4, half-maximal cytotoxic concentration: 19200 nM
Compound 4: the middle estimate sits 2.6-fold (0.42 log units) above what was measured; measured number inside the range.
By their numbers in this assay, from the lowest: compounds 4 and 3 (each within the scatter of the next); then compound 2. At a limit, above all of these: compound 1.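

Working notes: the carbonyl carbon is changed here for the first time, and in this assay dimethylamino in place of ethoxy gives a 1.5-fold lower number from compound 3 to compound 4 (0.17 log units; within the scatter). On the trifluoromethyl compound, then, the ethoxycarbonyl group can give way to dimethylcarbamoyl without a read-out change beyond the scatter, a finding that rests on this one pair. No measurement shown here accounts for the step. Still open, going by these compounds, is whether the same swap behaves alike with fluoro or nitro on the aromatic carbon. Also open, on these data alone, is whether a carboxylic acid or a morpholine amide at the carbonyl carbon would shift the number beyond the scatter.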